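This account rests on a few compounds, and the source may have more. Where it says the series, first, only, none or still open, it means among the compounds named here.

In a functional assay on COLO 205 cells (Homo sapiens) for antiproliferative activity, read by MTT assay (on this read-out lower numbers stand for stronger inhibition and higher numbers for weaker inhibition), two compounds have been measured. Compound 1 `COc1ccc2nc(N(Cc3cc(-c4ccccc4F)no3)c3nc4ccc(F)cc4s3)sc2c1` gives 13400 nM in this assay. Compound 2 `FC(F)(F)Sc1ccc(-c2cc(CN(c3ncccn3)c3nc4ccccc4s3)on2)cc1` gives 10100 nM in this assay, a number that lies within the usual scatter of compound 1, so the two cannot be ranked. Compound 3 `FC(F)(F)Oc1ccc(-c2cc(CN(c3ncccn3)c3nc4ccccc4s3)on2)cc1` differs from compound 2 in one place: trifluoromethoxy in place of (trifluoromethyl)sulfanyl on an aromatic carbon. Going by the values given here, no measured pair shows this change, so any step is expected to stay within the scatter, in either direction. Compound 3 is therefore estimated at 12000 nM, with a range from 5000 nM to 30000 nM, an expected step of a 1.2-fold higher number from compound 2 to compound 3 (0.07 log units; within the scatter).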

Compound 3, half-maximal inhibitory concentration: 5690 nM
The estimate for compound 3 lay 2.1-fold (0.32 log units) above the measured number, within the range that was stated.
By their numbers in this assay, from the lowest: compounds 3, 2 and 1 (each within the scatter of the next, the first and the last beyond it).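

Going by these compounds alone, this is the first direct comparison at this position. In this assay, the change from 4-((trifluoromethyl)sulfanyl)phenyl to 4-(trifluoromethoxy)phenyl gives a 1.8-fold lower number from compound 2 to compound 3 (0.25 log units; within the scatter) and so does not separate the two compounds, which means this read-out cannot tell these two groups apart here. No measurement at hand bears on the reason for this result. As far as these compounds go, it remains open whether an amine, a carboxylic acid or a longer chain in this place would shift the number beyond the scatter. Also open, from the compounds shown here alone, is whether the same change would behave alike on the core of compound 1.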